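A few compounds are considered here, and "the series" means these few. Any claim that something is new, unique, unknown or untested is made for them only; others in the source may bear on it.

Measured in a functional assay on BXPC-3 cells (Homo sapiens) for cytotoxicity, read by MTT assay, with a stated time of 72 h; a higher number here means a weaker inhibitor, a lower number a stronger inhibitor:
compound 1 `COc1cc(NC2=CC(=O)c3ncncc3C2=O)cc(OC)c1OC`: 1600 nM
compound 2 `NC(=O)c1ccc(NC2=CC(=O)c3ncncc3C2=O)cc1`: a limit, > 10000 nM
compound 3 `COc1cc(NC2=CC(=O)c3ncncc3C2=O)cc(OC)c1`: 16300 nM

Compound 2 gives only a limit in this assay, > 10000 nM, and stands at the limit of > 10000 nM in this assay, at which 1 of the 3 values shown sits; no number is known for it. Among the compounds with values here, compounds 1 and 3 give numbers, and the single measured step, a 10-fold higher number from compound 1 to compound 3 (1.01 log units; beyond the scatter), concerns a methoxy on an aromatic carbon of the shared core, not the carbonyl carbon. Compound 4 `CCOC(=O)c1ccc(NC2=CC(=O)c3ncncc3C2=O)cc1` differs from compound 2 by ethoxy in place of amino on a carbonyl carbon. Within the data shown here, no measured step touches that carbonyl carbon, so nothing argues for a change in this assay beyond the scatter in either direction; the expectation for compound 4 rests on compound 2 alone. Compound 4 is expected near 12000 nM, within 3000 nM to 40000 nM. The step that the limit leaves unreadable from compound 2 to compound 4 is expected to be small, and compound 4 may again be reported only as a limit.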

Compound 4, half-maximal inhibitory concentration: 5900 nM
The estimate for compound 4 lay 2.0-fold (0.31 log units) above the measured number; the measured number falls inside the stated range.
By their numbers in this assay, from the lowest: compound 1; then compound 4; then compound 3.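

With ethoxycarbonyl in place of carbamoyl, compound 4 gives a number in this assay, 5900 nM, the first obtained on this carbonyl carbon. The change reads as an at least 1.6-fold lower number from compound 2 to compound 4 (0.22 log units; that floor lies within the scatter), so a shift beyond the scatter is not established. Its true size stays unreadable because compound 2 holds only a limit: the limit of > 10000 nM in this assay, at which 1 of the 4 values shown sits.

Open, from the compounds shown here alone, is whether a carboxylic acid or a longer chain such as propoxy on this carbonyl carbon would shift the number in this assay. Also open, going by these compounds, is how ethoxycarbonyl would read combined with the methoxy groups of compound 1.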